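The source may hold more compounds than are shown below. What is called first, only, known or untested is meant among the compounds shown, and "the series" means these compounds.

Measured so far in a functional assay on K562 cells (Homo sapiens) for inhibition, read by trypan blue exclusion, with a stated time of 72 h; a lower number here means a stronger inhibitor, a higher number a weaker inhibitor:
Compound 1 `Cn1c(=O)c(C(=O)Nc2ccc(F)cc2F)cc2cnc(Nc3ccc4[nH]ccc4c3)nc21` gives 5000 nM.
Compound 2 `Cn1c(=O)c(S(=O)(=O)c2ccc(F)cc2F)cc2cnc(Nc3ccc4sccc4c3)nc21` gives 500 nM.
Compound 3 `COc1ccc(Nc2ncc3cc(S(=O)(=O)c4ccc(Cl)cc4)c(=O)n(C)c3n2)cc1` gives 15000 nM.

Among these three numbers compound 2 stands lowest, and its gaps to compound 1 and to compound 3 both lie beyond the usual scatter of repeated measurements, so compound 2 is the strongest inhibitor of the three. Compound 1 and compound 3 each differ from compound 2 at more than one place, so no single structural change can be read off from them. The unmeasured compound 4 `Cc1cc2cc(Nc3ncc4cc(S(=O)(=O)c5ccc(F)cc5F)c(=O)n(C)c4n3)ccc2[nH]1` differs from compound 2 in one place only: 2-methyl-1H-indol-5-yl in place of 1-benzothiophen-5-yl on a nitrogen on an aromatic ring. Within the data shown here, no measured pair isolates this change, so its effect has to be guessed from the shared core and the values at hand. In this assay the expected step is a 1.3-fold lower number from compound 2 to compound 4 (0.10 log units; within the scatter), a small move towards a lower number that stays close to the scatter. Compound 4 is therefore estimated at 400 nM, with a range from 100 nM to 2000 nM.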

Compound 4, half-maximal inhibitory concentration: 750 nM
Compound 4: middle estimate off by 1.9-fold (0.27 log units), on the low side; measured number inside the range.
By their numbers in this assay, from the lowest: compounds 2 and 4 (each within the scatter of the next); then compound 1; then compound 3.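

In this assay, putting 2-methyl-1H-indol-5-yl in place of 1-benzothiophen-5-yl on a nitrogen on an aromatic ring gives a 1.5-fold higher number from compound 2 to compound 4 (0.18 log units; within the scatter). Among these compounds, this is the first comparison at this position in which only one place differs, and it shows that the two groups cannot be told apart here, even though the entering group counts one hydrogen-bond donor and no acceptor, while the leaving group counts no donor and one acceptor. No measurement shown here accounts for this result.

The compounds shown do not separate the contribution of the methyl from that of swapping sulfur for nitrogen, a question that plain 1H-indol-5-yl on the same core would address. Going by these compounds, it also remains open how this position would respond to a group carrying an amine or a carboxylic acid.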